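This account rests on a few compounds, and the source may have more. Where it says the series, first, only, none or still open, it means among the compounds named here.

Compound 1 `[O-][n+]1nc(NC2CCCCC2)[n+]([O-])c2ccccc21` carries a cyclohexyl group on a nitrogen attached to the shared core. In a functional assay on MOLT-4 cells (Homo sapiens) for cytotoxicity, read by MTT assay, with a stated time of 48 h (on this read-out higher numbers stand for weaker inhibition and lower numbers for stronger inhibition), compound 1 gives 1300 nM, the higher of the two numbers recorded here, although compound 2 `O=[N+]([O-])c1ccc(CNc2n[n+]([O-])c3ccccc3[n+]2[O-])cc1` gives 800 nM and this gap lies within the scatter of repeated measurements. For compound 3 `CCN(CC)c1n[n+]([O-])c2ccccc2[n+]1[O-]` the assay reports only a limit, > 17600 nM. Compound 4 `[O-][n+]1nc(Nc2ccccc2)[n+]([O-])c2ccccc21` has not yet been measured; it differs from compound 1 by phenyl in place of cyclohexyl on a nitrogen on an aromatic ring. Going by the values given here, no measured pair shows this change, so the step of a 1.3-fold lower number from compound 1 to compound 4 (0.11 log units; within the scatter) is expected to be modest, with no confident direction and possibly none beyond the scatter. Compound 4 is therefore estimated at 1000 nM, within a range from 300 nM to 3500 nM.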

Compound 4, half-maximal inhibitory concentration: 1400 nM
Compound 4: the middle estimate sits 1.4-fold (0.15 log units) below what was measured, and the stated range covers the measured number.
By their numbers in this assay, from the lowest: compounds 2, 1 and 4 (each within the scatter of the next). At a limit, above all of these: compound 3.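

In this assay, phenyl in place of cyclohexyl on this nitrogen gives a 1.1-fold higher number from compound 1 to compound 4 (0.03 log units; within the scatter), so exchanging the non-aromatic ring for the aromatic one makes no discernible difference. This is the only direct comparison at this position among the compounds shown, and either ring gives a similar result there. Nothing measured here explains this similarity. Still open, going by these compounds, is how a carboxylic acid, an amine or a longer alkyl chain would behave on the same nitrogen.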